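A few compounds are considered here, and "the series" means these few. Any claim that something is new, unique, unknown or untested is made for them only; others in the source may bear on it.

Working notes on the series. In a functional assay on Bel-7402 cells (Homo sapiens) for inhibition, read by MTT assay, with a stated time of 24 h, tested at 10 ug/mL (a lower number here means less inhibition of growth, a higher number more inhibition of growth at the concentration tested), compound 1 `O=C(CCCCC1CCSS1)Nc1cccc(C(F)(F)F)c1` gives 4.43% and compound 2 `O=C(CCCCC1CCSS1)Nc1cccc2ccccc12` gives 6.27%. These two values lie within the scatter of each other, so compound 2 cannot be separated from compound 1 on these numbers. Compound 3 `O=C(CCCCC(S)CCS)Nc1cccc2ccccc12` differs from compound 2 by a group of 5 heavy atoms (3 carbon, 2 sulfur; no ring) in place of a group of 5 heavy atoms (3 carbon, 2 sulfur; one five-membered non-aromatic ring with 2 hetero atoms), on a saturated chain carbon, four bonds along the chain from a carbonyl carbon. Among the compounds with values here, no measured pair shows a change of this kind, so no shift beyond the scatter in this assay is assumed. The expected size is a number 1.7 percentage points higher from compound 2 to compound 3 (within the scatter), which is within the scatter. For compound 3 the estimated value is 8%, with an expected range of 1% to 20%.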

Compound 3, percent growth inhibition at one concentration: "not active" (no number reported)
No number was reported for compound 3; there is nothing to compare the estimate with.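

In this assay, within the data shown here, compound 3 carries no number, so no step from compound 2 to compound 3 can be read. No evidence on hand bears on this result. The compounds shown leave open how the 1,3-disulfanylpropyl group compares numerically with the ring it replaces.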